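This account rests on a few compounds, and the source may have more. Where it says the series, first, only, none or still open, it means among the compounds named here.

Measured so far:
compound 1 `COc1ccc(C2N=C(SCc3ccccc3)NC(C)=C2C(=O)Nc2ccc(F)cc2)cc1OC` — 3.6%
compound 2 `COc1ccc(C2N=C(SCc3cccc(Cl)c3)NC(C)=C2C(=O)Nc2ccc(F)cc2)cc1OC` — 20.1%
compound 3 `CC1=C(C(=O)Nc2ccc(Br)cc2)C(c2ccc(Cl)cc2Cl)N=C(SCc2ccccc2)N1` — 24.2%

In a functional assay on the whole organism (artery, strain albino) with Rattus norvegicus as the target, with a stated time of 360 min, at a dose of 10 mg/kg by the oral route (a lower number here means less inhibition, a higher number more inhibition at the dose given (going by the name of the read-out)), compound 3 gives 24.2%, a number that lies beyond the scatter above compound 1 but within the scatter of compound 2. Compound 4 `CC1=C(C(=O)Nc2ccc(Br)cc2)C(c2ccc(Cl)cc2Cl)N=C(SCc2ccc(F)cc2)N1` has not yet been measured. It differs from compound 3 in one place: fluoro in place of hydrogen on an aromatic carbon.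

Among the measured compounds shown here, only one measured step bears on this change, the one from compound 1 to compound 2, where a chloro also entered on an aromatic carbon in place of hydrogen: a number 16.5 percentage points higher from compound 1 to compound 2 (beyond the scatter). For the measured compounds named here, no measured pair shows a fluoro entering on an aromatic carbon, and no pair shows a change para to a large group, so the expectation rests on that single step alone. A fluoro is a smaller entering group than a chloro, so a smaller shift in this assay is expected, upward if at all, and possibly not beyond the scatter.

Compound 4 is therefore estimated at 30%, within 14% to 46%, which means an expected step of a number 5.8 percentage points higher from compound 3 to compound 4 (within the scatter).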

Compound 4, a percentage reported as inhibition, in the whole organism at one dose (the size of the read-out at that dose, not a potency): 40.7%
Compound 4: middle estimate off by 10.7 percentage points, on the low side, and the stated range covers the measured number.
By their numbers in this assay, from the lowest: compound 1; then compounds 2 and 3 (each within the scatter of the next); then compound 4.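

Going from benzyl to 4-fluorobenzyl on the sulfanyl side chain, this assay gives a number 16.5 percentage points higher from compound 3 to compound 4 (beyond the scatter) as its step, so a single fluoro on an aromatic carbon, para to a large group, is enough to move this read-out clearly. That step is the same size as a number 16.5 percentage points higher from compound 1 to compound 2 (beyond the scatter), where a chloro entered the benzyl group of a different parent compound. On these two pairs alone, then, the fluoro did no less than the chloro, and a halogen on this benzyl group raised the inhibition in both parents.

From the compounds shown here alone, whether an amine, a carboxylic acid or a methoxy group on that same carbon would also raise the number remains open. What lies behind the rise also stays unexplained, as no supporting measurement bears on it.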